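The source may hold more compounds than are shown below. What is called first, only, known or untested is meant among the compounds shown, and "the series" means these compounds.

Compounds measured in an ADME assay on HepG2 cells (Homo sapiens) for cytotoxicity, read by MTT assay, with a stated time of 48 h (a higher number here means a weaker inhibitor, a lower number a stronger inhibitor), so far:

- Compound 1 `O=S(=O)(c1ccc(-c2ccc3ncnc(Nc4ccc(O)c(Cl)c4)c3c2)cc1)N1CCOCC1` gives > 15000 nM (a limit)
- Compound 2 `O=S(=O)(c1ccc(-c2ccc3ncnc(Nc4ccc(OCc5cccc(Br)c5)c(Cl)c4)c3c2)cc1)N1CCOCC1` gives > 15000 nM (a limit)
- Compound 3 `O=S(=O)(c1ccc(-c2ccc3ncnc(Nc4ccc(OCc5ccc(F)cc5)c(Cl)c4)c3c2)cc1)N1CCOCC1` gives > 15000 nM (a limit)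

None of these entries is a true number, since each is a limit of the assay. Compound 3 shares its position with the other two (the limit of > 15000 nM in this assay, at which 3 of the 3 values shown sit). Compound 4 `O=S(=O)(c1ccc(-c2ccc3ncnc(Nc4ccc(OCc5ccc(C(F)(F)F)c(F)c5)c(Cl)c4)c3c2)cc1)N1CCOCC1` differs from compound 3 in one place (3-fluoro-4-(trifluoromethyl)phenyl in place of 4-fluorophenyl on a saturated chain carbon bound to an oxygen on an aromatic ring). There, 3-fluoro-4-(trifluoromethyl)phenyl takes the place of 4-fluorophenyl, on a saturated chain carbon bound to an oxygen on an aromatic ring.

Going by the values given here, the closest precedent is a change at that same place (a step that the two limits leave unreadable from compound 2 to compound 3). Two further changes put a benzyl group on the oxygen (a step that the two limits leave unreadable from compound 1 to compound 2 and a step that the two limits leave unreadable from compound 1 to compound 3). None of these three has a readable size, so they point to no direction, and no step beyond the usual scatter is expected in this assay. The expected change is small (a step that the limit leaves unreadable from compound 3 to compound 4). For compound 4 the estimated value is 20000 nM, with an expected range from 8000 nM to 50000 nM, and the assay will probably report only a limit again.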

Compound 4, half-maximal inhibitory concentration: > 15000 nM
Compound 4: a limit, no number (the forecaster's own chance of this, stated with the estimate: 80%); the middle value is on the limit's open side.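

Compound 4 also returns a limit and not a number, so the steps to it from compound 1, compound 2 and compound 3 cannot be read: the limit of > 15000 nM in this assay, at which 4 of the 4 values shown sit. The compounds shown leave open what true values lie behind that limit, and whether any change on the oxygen alters them.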